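Uncapping an amine on a quinoline side chain

The compounds below may be only part of what the source reports. "The series", "measured", "known", "first", "only" and "open" are said of these compounds alone.

Compound 1 `O=C(Nc1cccc2cccnc12)c1ncccn1`: > 10000 nM
Compound 2 `Cc1cnc(C(=O)Nc2cc(OCCC3CCNCC3)cc3cccnc23)cn1`: 8330 nM
Compound 3 `CC(C)(C)OC(=O)NCCOc1cc(NC(=O)c2ncccn2)c2ncccc2c1`: > 10000 nM

All three were tested in a functional assay on BXPC-3 cells (Homo sapiens) for inhibition, read by MTT assay, with a stated time of 72 h; on this read-out lower numbers stand for stronger inhibition and higher numbers for weaker inhibition. For compound 3 the result is only a limit of the assay, not a number, and it shares that limit with one other compound (the limit of > 10000 nM in this assay, at which 2 of the 3 values shown sit). Compound 1 also stops at a limit. Among the measured compounds shown here, only compound 2 gives a number, 8330 nM, and that is the sole measured value to lean on.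

Compound 4 `O=C(Nc1cc(OCCC2CCNCC2)cc2cccnc12)c1ncccn1` differs from compound 3 by piperidin-4-yl in place of (tert-butoxycarbonyl)amino on a saturated chain carbon, two bonds along the chain from an oxygen on an aromatic ring. For the measured compounds named here, since compound 3 starts from a limit, no measured step exists; the expected step from compound 3 to compound 4 an at least 1.1-fold lower number from compound 3 to compound 4 (0.04 log units; that floor lies within the scatter) is a small move toward stronger inhibition, not clearly beyond the scatter. Compound 4 is estimated at 9000 nM, within 3000 nM to 30000 nM.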

Compound 4, half-maximal inhibitory concentration: > 10000 nM
Compound 4: a limit, no number; the forecaster's own chance of this, stated with the estimate: 45%; middle value at least 1.1-fold (0.04 log units) away from the limit.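

Putting piperidin-4-yl in place of (tert-butoxycarbonyl)amino does not lift compound 4 off the assay limit, and it joins most of the set there: the limit of > 10000 nM in this assay, at which 3 of the 4 values shown sit. The steps to compound 4 from compound 1 and from compound 3 therefore cannot be read. Pyrimidin-2-yl in place of 5-methylpyrazin-2-yl on the carbonyl carbon gives an at least 1.2-fold higher number from compound 2 to compound 4 (0.07 log units; that floor lies within the scatter), so this change shows no clear effect.

As far as these compounds go, whether a plain primary amine or a longer chain at this position would give a measurable number stays open.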